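The source may hold more compounds than are shown below. What is called first, only, known or untested is meant among the compounds shown, and "the series" means these compounds.

Working notes on the series. Compound 1 `COc1cc2c(Oc3ccc(NC(=O)c4cn(-c5ccccc5OC)cn4)cc3F)ccnc2cc1OCCCN1CCCCC1` gives 120 nM in a functional assay on A549 cells (Homo sapiens) for cytotoxicity, read by MTT assay, with a stated time of 72 h; on this read-out higher numbers stand for weaker inhibition and lower numbers for stronger inhibition. Compound 2 `COc1cc2c(Oc3ccc(NC(=O)c4cn(-c5cc(C)ccc5C)cn4)cc3F)ccnc2cc1OCCCN1CCCCC1` gives 510 nM in this assay, the highest of the two numbers measured; its nearest neighbour is compound 1, and the step of a 4.3-fold higher number from compound 1 to compound 2 (0.63 log units; beyond the scatter) shows that the aryl on the ring nitrogen moves the number by a modest amount. Compound 3 `COc1cc2c(Oc3ccc(NC(=O)c4cn(-c5ccc(Cl)cc5)cn4)cc3F)ccnc2cc1OCCCN1CCCCC1` carries the change (4-chlorophenyl in place of 2,5-dimethylphenyl on an aromatic nitrogen). Among the measured compounds shown here, no measured step covers 4-chlorophenyl at this position; the only step that bears on the change is the one from compound 1 to compound 2, modest in size, and it gives no direction for a group that differs from both. The expectation for compound 3 is therefore a number near compound 2 in this assay, with the estimated step of a 1.7-fold lower number from compound 2 to compound 3 (0.23 log units; within the scatter) leaning slightly downward. The estimate for compound 3 is 300 nM, within the range 90 nM to 1000 nM.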

Compound 3, half-maximal inhibitory concentration: 6560 nM
For compound 3 the middle estimate is 22-fold (1.34 log units) below the measured one; the whole stated range lies below it.
By their numbers in this assay, from the lowest: compound 1; then compound 2; then compound 3.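

In this assay, the aryl group on the aromatic nitrogen turns out to matter far more than the earlier modest step suggested: a 13-fold higher number from compound 2 to compound 3 (1.11 log units; beyond the scatter) and a 55-fold higher number from compound 1 to compound 3 (1.74 log units; beyond the scatter) are both large. Among the three compounds, 2-methoxyphenyl and 2,5-dimethylphenyl give the two lower numbers, while 4-chlorophenyl gives the highest, so this position tolerates some aryl changes far better than others. Nothing available explains the size of this jump.

The compounds shown do not separate the effect of chlorine itself from that of where the substituent sits on the phenyl ring, since 4-chlorophenyl differs from both other groups in both respects. A 2-chlorophenyl or a 4-methoxyphenyl group on the same nitrogen would bear directly on that question.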